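Aromatic substituent changes in a carbamate polyketide series

This account rests on a few compounds, and the source may have more. Where it says the series, first, only, none or still open, it means among the compounds named here.

Compound 1 `C=C/C=C\[C@H](C)[C@H](OC(N)=O)[C@@H](C)[C@H](O)[C@@H](C)C/C(C)=C\[C@H](C)[C@@H](O)[C@@H](C)/C=C\CCc1cccc(OC)c1` gives 600 nM in a functional assay on A549 cells (Homo sapiens) for cytotoxicity; on this read-out higher numbers stand for weaker inhibition and lower numbers for stronger inhibition.
Compound 2 `C=C/C=C\[C@H](C)[C@H](OC(N)=O)[C@@H](C)[C@H](O)[C@@H](C)C/C(C)=C\[C@H](C)[C@@H](O)[C@@H](C)/C=C\CCc1cccc(F)c1` gives 650 nM in this assay.
Compound 3 `C=C/C=C\[C@H](C)[C@H](OC(N)=O)[C@@H](C)[C@H](O)[C@@H](C)C/C(C)=C\[C@H](C)[C@@H](O)[C@@H](C)/C=C\CCc1cc(F)cc(F)c1` gives 1000 nM in this assay.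

Compound 1 has the lowest of the three numbers, but the steps of a 1.1-fold higher number from compound 1 to compound 2 (0.03 log units; within the scatter) and a 1.7-fold higher number from compound 1 to compound 3 (0.22 log units; within the scatter) are both within the scatter, so no order among the three can be claimed. Compound 4 `C=C/C=C\[C@H](C)[C@H](OC(N)=O)[C@@H](C)[C@H](O)[C@@H](C)C/C(C)=C\[C@H](C)[C@@H](O)[C@@H](C)/C=C\CCc1cc(O)cc(O)c1` differs from compound 1 by 3,5-dihydroxyphenyl in place of 3-methoxyphenyl on a saturated chain carbon, two bonds along the chain from a double-bonded chain carbon. Among the compounds with values here, the steps that bear on this change are those at the same place on the chain, a 1.7-fold higher number from compound 1 to compound 3 (0.22 log units; within the scatter), and the smaller exchange on the ring, a 1.1-fold higher number from compound 1 to compound 2 (0.03 log units; within the scatter); neither moved the number beyond the scatter. Within the data shown here, no measured step involves a hydroxy group, so the expectation for compound 4 rests on these two steps alone. Compound 4 is therefore expected to show a step of a 1.3-fold higher number from compound 1 to compound 4 (0.12 log units; within the scatter), within the scatter, and its value in this assay is estimated at 800 nM, with a range of 300 nM to 2500 nM.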

Compound 4, half-maximal inhibitory concentration: 310 nM
Compound 4: the middle estimate sits 2.6-fold (0.41 log units) above what was measured; the range from low to high includes it.
By their numbers in this assay, from the lowest: compounds 4, 1, 2 and 3 (each within the scatter of the next, the first and the last beyond it).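

Within the data shown here, the exchange for 3,5-dihydroxyphenyl on this saturated chain carbon gives the first steps in this assay that lie beyond the scatter: a 3.2-fold lower number from compound 3 to compound 4 (0.51 log units; beyond the scatter) and a 2.1-fold lower number from compound 2 to compound 4 (0.32 log units; beyond the scatter). Against the methoxy ring, however, the step stays within it: a 1.9-fold lower number from compound 1 to compound 4 (0.29 log units; within the scatter). Nothing available gives a reason for these steps.

As far as these compounds go, it remains open whether a single hydroxy group on the ring would give the same steps, and how an amine or a carboxylic acid there would read. From the compounds shown here alone, a longer chain carrying the 3,5-dihydroxyphenyl ring is equally open.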